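Chloro to diisopropylamino on the shared core

The source may report more compounds than this note shows. Statements on the series, on what has been measured and on what is new or still open speak of the compounds shown alone.

In a functional assay on HL-60 cells (Homo sapiens) for antiproliferative activity, read by MTT assay, with a stated time of 48 h (a higher number here means a weaker inhibitor, a lower number a stronger inhibitor), compound 1 `CC(=O)OC/C1=C/C[C@](C)(CCC=C(C)C)/C=C/[C@@H](OC(=O)C=C(C)C)[C@](C)(O)/C=C/C1=O` gives 2950 nM and compound 2 `CC(C)=CCC[C@]1(C)/C=C/[C@@H](OC(=O)C=C(C)C)[C@](C)(O)/C=C/C(=O)/C(CCl)=C\C1` gives 160 nM. Compound 2 therefore holds the lower of the two numbers and is the stronger inhibitor so far.

Compound 3 `CC(C)=CCC[C@]1(C)/C=C/[C@@H](OC(=O)C=C(C)C)[C@](C)(O)/C=C/C(=O)/C(CN(C(C)C)C(C)C)=C\C1` keeps the core of compound 2 and changes one group: diisopropylamino in place of chloro on a saturated chain carbon bound to a double-bonded ring carbon. In words, diisopropylamino stands in place of chloro on a saturated chain carbon bound to a double-bonded ring carbon.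

For the measured compounds named here, only one measured step bears on this change. It is the swap of acetoxy for chloro at that same place, which gave an 18-fold lower number from compound 1 to compound 2 (1.27 log units; beyond the scatter), a large step beyond the scatter. In these two compounds, then, the number responds strongly to the group carried there. No amino group has been measured at this place, so the size of the next step is uncertain. Starting from the lower number of the pair, a rise in this assay seems more likely than a further drop. The expected change is a 4.4-fold higher number from compound 2 to compound 3 (0.64 log units; beyond the scatter). For compound 3 the estimated value is 700 nM, with an expected range from 170 nM to 3000 nM.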

Compound 3, half-maximal inhibitory concentration: 740 nM
Compound 3: the middle estimate sits 1.1-fold (0.02 log units) below what was measured; low and high end bracket the measured number.
By their numbers in this assay, from the lowest: compound 2; then compound 3; then compound 1.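

In this assay, three groups can now be compared on a saturated chain carbon bound to a double-bonded ring carbon, and the only amine among them falls in the middle. Chloro keeps the lowest number, since swapping it for diisopropylamino gives a 4.6-fold higher number from compound 2 to compound 3 (0.67 log units; beyond the scatter) as a modest loss, yet the amine still does better than acetoxy, with a 4.0-fold lower number from compound 1 to compound 3 (0.60 log units; beyond the scatter) as a modest gain. So the large effect of chloro seen earlier is not simply all or nothing: a group much larger by heavy-atom count than chloro still leaves the number lower than acetoxy does, and nothing available here accounts for this order.

These compounds leave open whether a smaller amine such as dimethylamino, a ring amine such as morpholine, or another halogen such as bromo at this place would fall closer to chloro or to diisopropylamino. All three numbers also come from a single cell line and a single read-out, so whether the same order holds in other cells remains an open question.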